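Fluoro in Place of Methoxy: Expecting Compound 4

The source may report more compounds than this note shows. Statements on the series, on what has been measured and on what is new or still open speak of the compounds shown alone.

Three compounds have been tested in a functional assay on HOP-62 cells (Homo sapiens) for inhibition, read by sulforhodamine B assay, with a stated time of 48 h; a lower number here means a stronger inhibitor of growth, a higher number a weaker inhibitor of growth:
Compound 1, `CCOC(=O)[C@H](CCC(=O)O)NC(=O)c1ccc(CNc2nc3cc(N)cc(N)c3nc2-c2ccccc2)cc1`, gives < 100000 nM, which is a limit of the assay rather than a number.
Compound 2, `CCOC(=O)[C@H](CCC(=O)O)NC(=O)c1ccc(Sc2nc3cc(N)cc(N)c3nc2-c2ccccc2)cc1`, gives 15500 nM.
Compound 3, `COc1ccc(Sc2nc3cc(N)cc(N)c3nc2-c2ccccc2)cc1`, gives < 100000 nM, again a limit of the assay.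

Compound 3 therefore stands without a number in this assay; it sits at the limit of < 100000 nM in this assay, at which 2 of the 3 values shown sit, so its place among the three cannot be fixed more closely than that. Only compound 2 has a measured number, and no pair of these compounds differs in a single place, so no measured step exists to lean on.

Compound 4, `Nc1cc(N)c2nc(-c3ccccc3)c(Sc3ccc(F)cc3)nc2c1`, is compound 3 with one change: fluoro in place of methoxy on an aromatic carbon. Because compound 3 shows only < 100000 nM, the size of the step to compound 4 can only be guessed. A swap of one small group for another on the outer ring is expected to move the number little, if at all, beyond the usual scatter; the expected step is a step that the limit leaves unreadable from compound 3 to compound 4.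

For compound 4 the estimate in this assay is 60000 nM, with a likely range from 15000 nM to 150000 nM, and a fair chance that the assay again reports only a limit.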

Compound 4, concentration for 50% growth inhibition: 16600 nM
Compound 4: middle estimate off by 3.6-fold (0.56 log units), on the high side, and the stated range covers the measured number.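

The step from compound 3 to compound 4 cannot be read, because compound 3 has only a limit of the assay rather than a number: the limit of < 100000 nM in this assay, at which 2 of the 4 values shown sit.

The compounds shown leave open how large a change in this assay comes with going from 4-methoxyphenyl to 4-fluorophenyl, and even in which direction it runs.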